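Cyclohexyl in Place of 4-Methylphenyl: Compound 4 Foreseen

A few compounds are considered here, and "the series" means these few. Any claim that something is new, unique, unknown or untested is made for them only; others in the source may bear on it.

The study examines antiproliferative activity in a functional assay on MCF7 cells (Homo sapiens) for antiproliferative activity, read by MTT assay, with a stated time of 72 h; a higher number here means a weaker inhibitor, a lower number a stronger inhibitor. Compound 1 `Cc1ccc(N2C(=O)COc3ccc(-c4cnc5ccccc5c4)cc32)cc1` carries a 4-methylphenyl on the amide-type nitrogen of its core. For compound 1 this assay reports only a limit, > 40000 nM, not a number. Among the compounds with values here, that limit, (the limit of > 40000 nM in this assay, at which 1 of the 3 values shown sits), marks where compound 1 stands among the three values so far: at the very edge of what this assay resolves.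

Two other compounds were measured. Compound 2 `O=C1COc2ccc(-c3cnc(Cl)c(NS(=O)(=O)c4ccc(F)cc4)c3)cc2N1c1ccc(F)cc1` gives 32600 nM in this assay. Compound 3 `COc1ccc(N2C(=O)COc3ccc(-c4ccc(O)cc4)cc32)cc1`, which carries a methoxyphenyl on the same nitrogen, gives 17300 nM. Neither reaches strong inhibition.

Compound 4 `O=C1COc2ccc(-c3cnc4ccccc4c3)cc2N1C1CCCCC1` differs from compound 1 in one place, (cyclohexyl in place of 4-methylphenyl on an amide-type nitrogen in a ring), the 4-methylphenyl giving way to a cyclohexyl on the amide-type nitrogen in the ring. Within the data shown here, no measured pair in the set isolates this change, so the size of the step rests on expectation alone. Since compound 1 sits at a limit, the step from compound 1 to compound 4 is expected to be small or absent within the scatter, with the measured value of compound 4 most likely remaining near the limit. Compound 4 is estimated to give 35000 nM in this assay, with a range from 12000 nM to 100000 nM. Accordingly, the step of an at least 1.1-fold lower number from compound 1 to compound 4 (0.05 log units; that floor lies within the scatter) is expected to be modest.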

Compound 4, half-maximal inhibitory concentration: > 40000 nM
Compound 4 was reported as a limit (the forecaster's own chance of this, stated with the estimate: 50%); middle value at least 1.1-fold (0.05 log units) from the limit.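

In this assay compound 4 is reported only as a limit, > 40000 nM. Compound 1 also stands at a limit, so no step between compound 1 and compound 4 can be read: the limit of > 40000 nM in this assay, at which 2 of the 4 values shown sit.

The compounds shown leave open how far cyclohexyl and 4-methylphenyl on the amide-type nitrogen differ in this assay, since neither compound has a number there.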